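The source may hold more compounds than are shown below. What is called first, only, known or untested is meant among the compounds shown, and "the series" means these compounds.

Compound 1 `COc1c(Br)cc(Br)cc1Oc1ccc(Br)cc1Br`: 34.5 ug/mL
Compound 2 `BrCCCCCCOc1c(Br)cc(Br)cc1Oc1ccc(Br)cc1Br`: 33.8 ug/mL
Compound 3 `BrCCCCCOc1c(Br)cc(Br)cc1Oc1ccc(Br)cc1Br`: 29.5 ug/mL

In a functional assay on U-937 cells (Homo sapiens) for cytotoxicity, read by MTT assay, with a stated time of 24 h (on this read-out higher numbers stand for weaker inhibition and lower numbers for stronger inhibition), compound 3 gives 29.5 ug/mL, the lowest of the three numbers, although its gaps to the others, a 1.1-fold lower number from compound 2 to compound 3 (0.06 log units; within the scatter) and a 1.2-fold lower number from compound 1 to compound 3 (0.07 log units; within the scatter), both lie within the scatter. Compound 4 `OCCCOc1c(Br)cc(Br)cc1Oc1ccc(Br)cc1Br` differs from compound 3 by hydroxy in place of 2-bromoethyl on a saturated chain carbon, three bonds along the chain from an oxygen on an aromatic ring. Among the measured compounds shown here, the steps that bear on this change are the earlier alterations of the same chain: a 1.0-fold lower number from compound 1 to compound 2 (0.01 log units; within the scatter), a 1.2-fold lower number from compound 1 to compound 3 (0.07 log units; within the scatter) and a 1.1-fold lower number from compound 2 to compound 3 (0.06 log units; within the scatter), none of which moved the number beyond the scatter. No step beyond the scatter is therefore expected in this assay for compound 4. Compound 4 is estimated at 30 ug/mL, with a range from 15 ug/mL to 60 ug/mL, which is expected to mean a step of a 1.0-fold higher number from compound 3 to compound 4 (0.01 log units; within the scatter).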

Compound 4, half-maximal inhibitory concentration: 32.3 ug/mL
Estimate against measurement, compound 4: 1.1-fold (0.03 log units) below; the range from low to high includes it.
By their numbers in this assay, from the lowest: compounds 3, 4, 2 and 1 (each within the scatter of the next).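

In this assay, hydroxy in place of 2-bromoethyl, three bonds along the chain from an oxygen on an aromatic ring, puts a hydrogen-bond donor and acceptor on a chain that had ended in bromine, yet the number stays within the scatter (a 1.1-fold higher number from compound 3 to compound 4 (0.04 log units; within the scatter)). The same holds against the other two compounds (a 1.0-fold lower number from compound 2 to compound 4 (0.02 log units; within the scatter)) (a 1.1-fold lower number from compound 1 to compound 4 (0.03 log units; within the scatter)), so among these compounds the chain bromine is not required for this level of cytotoxicity. No measurement shown accounts for this insensitivity.

From the compounds shown here alone, whether an amine, a carboxylic acid or a much longer chain at this position would move the number beyond the scatter remains open.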